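Benzoxazole anilides: methyl-to-fluoro swap in C6 cytotoxicity

This account rests on a few compounds, and the source may have more. Where it says the series, first, only, none or still open, it means among the compounds named here.

Measured so far:
- compound 1, `CN(C)CCCN1CCN(CC(=O)Nc2ccc(-c3nc4cc(F)ccc4o3)cc2)CC1`: 27500 nM
- compound 2, `Cc1ccc2oc(-c3ccc(NC(=O)CN4CCN(CCCN(C)C)CC4)cc3)nc2c1`: 1810 nM
- compound 3, `Cc1ccc2oc(-c3ccc(NC(=O)CCl)cc3)nc2c1`: 4040 nM

In a functional assay on C6 cells (Rattus norvegicus) for cytotoxicity, read by MTT assay, with a stated time of 24 h (on this read-out lower numbers stand for stronger inhibition and higher numbers for weaker inhibition), compound 2 gives 1810 nM and compound 1 gives 27500 nM. Among the measured compounds shown here, the single change between them, (fluoro in place of methyl on an aromatic carbon), made a large step, a 15-fold higher number from compound 2 to compound 1 (1.18 log units; beyond the scatter). Compound 3 gives 4040 nM and carries a different core; how it differs from compound 2 is not broken down here.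

Compound 4, `O=C(CCl)Nc1ccc(-c2nc3cc(F)ccc3o2)cc1`, is not yet measured. It differs from compound 3 by fluoro in place of methyl on an aromatic carbon, the same change at the same place as from compound 2 to compound 1. Because the earlier step was a 15-fold higher number from compound 2 to compound 1 (1.18 log units; beyond the scatter), the number for compound 4 is expected to rise as well, but the change now sits on a different core, so the step is estimated smaller, a 4.0-fold higher number from compound 3 to compound 4 (0.60 log units; beyond the scatter). Compound 4 is estimated at 16000 nM, expected between 5000 nM and 60000 nM.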

Compound 4, half-maximal inhibitory concentration: 2990 nM
Estimate against measurement, compound 4: 5.4-fold (0.73 log units) above, outside the stated range (below it).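

On the second core the swap gives a 1.4-fold lower number from compound 3 to compound 4 (0.13 log units; within the scatter), so in this assay it leaves the number in place there, unlike on the first core. Across these four compounds, the swap of fluoro for methyl therefore does not transfer as a fixed step, and its size depends on the core that carries it: the same change on two cores in this assay, a 15-fold higher number (1.18 log units; beyond the scatter) from compound 2 to compound 1 and a 1.4-fold lower number (0.13 log units; within the scatter) from compound 3 to compound 4, 21-fold (1.31 log units) apart, beyond the scatter of two such steps With one pair per core, this does not show which feature of the cores sets the gap, nor what the swap would do on a further core.

Still open, on these data alone, is whether other groups on the same aromatic carbon, such as chloro or methoxy, would follow the same split between the cores. Also open, as far as these compounds go, is how a core ending in a carboxylic acid or a shorter amine chain would take the swap.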